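Moving the halogen on the thiophene-attached phenyl ring

The source may hold more compounds than are shown below. What is called first, only, known or untested is meant among the compounds shown, and "the series" means these compounds.

Measured compounds in a functional assay on CHO cells for agonist activity at adenosine receptor A1 (Homo sapiens), read by fluorescence and ERK phosphorylation, with stated times of 30 min and 1.5 h, tested at 10 uM; a lower number here means a weaker effect, a higher number a stronger effect of the compound at the concentration tested:
compound 1 `Nc1scc(-c2cccc(F)c2)c1C(=O)c1ccc(Cl)cc1` gives 90%
compound 2 `Nc1scc(-c2ccc(F)cc2)c1C(=O)c1ccc(Cl)cc1` gives 61%
compound 3 `Nc1scc(-c2cccc(Cl)c2)c1C(=O)c1ccc(Cl)cc1` gives 75%

Compound 3 stands second highest of the three, a number 15 percentage points lower from compound 1 to compound 3 (beyond the scatter) and a number 14 percentage points higher from compound 2 to compound 3 (beyond the scatter). Compound 4 `Nc1scc(-c2ccc(Br)cc2)c1C(=O)c1ccc(Cl)cc1` is not yet measured; it differs from compound 3 by 4-bromophenyl in place of 3-chlorophenyl on an aromatic carbon. Among the measured compounds shown here, two measured steps bear on this. The shift of the halogen from the 3-position to the 4-position was seen as a number 29 percentage points lower from compound 1 to compound 2 (beyond the scatter), and the swap of fluoro for chloro as a number 15 percentage points lower from compound 1 to compound 3 (beyond the scatter). The change to compound 4 combines a halogen shift with a heavier halogen, so a modest drop in this assay is expected, a number 20 percentage points lower from compound 3 to compound 4 (beyond the scatter). Compound 4 is estimated at 55%, within 35% to 75%.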

Compound 4, a percentage reported as activity, at one concentration (the size of the read-out at that concentration, not a potency): 46%
Compound 4: middle estimate off by 9 percentage points, on the high side; measured number inside the range.
By their numbers in this assay, from the lowest: compound 4; then compound 2; then compound 3; then compound 1.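

In this assay, the halogen matters even with its ring position held: bromo in place of fluoro gives a number 15 percentage points lower from compound 2 to compound 4 (beyond the scatter), in the same direction as the chloro for fluoro step. Changing the halogen and its ring position together gives a number 29 percentage points lower from compound 3 to compound 4 (beyond the scatter), and the full change across the set gives a number 44 percentage points lower from compound 1 to compound 4 (beyond the scatter), leaving compound 4 lowest of the four. Nothing available here explains these drops. Going by these compounds, whether an amine or a methoxy group in place of the halogen would keep or lose the effect remains open.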